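Prenyloxy for ethoxy on the isonicotinoyl hydrazide

A few compounds are considered here, and "the series" means these few. Any claim that something is new, unique, unknown or untested is made for them only; others in the source may bear on it.

Three cyclopropane carbohydrazides sharing one aryl ether core have been tested in a functional assay on U-373MG ATCC cells (Homo sapiens) for inhibition, read by MTT assay, with a stated time of 72 h; a lower number here means a stronger inhibitor, a higher number a weaker inhibitor. Compound 1 `CCOc1ccc(C2CC2C(=O)NNC(=O)c2ccncc2)cc1` gives 63000 nM. Compound 2 `CCOc1ccc(C2CC2C(=O)NNc2nncc3ccccc23)cc1` gives 91000 nM, and compound 3 `CC(C)=CCOc1ccc(C2CC2C(=O)NNc2nncc3ccccc23)cc1` gives 81000 nM; the gaps between compound 1 and each of these lie within the scatter, so the three numbers stand together rather than in any order. Compound 4 `CC(C)=CCOc1ccc(C2CC2C(=O)NNC(=O)c2ccncc2)cc1` has not been measured. It differs from compound 1 by 2-methylprop-1-en-1-yl in place of methyl on a saturated chain carbon bound to an oxygen on an aromatic ring. Going by the values given here, the one measured step that bears on this change is a 1.1-fold lower number from compound 2 to compound 3 (0.05 log units; within the scatter), the same exchange made on the phthalazinyl hydrazide pair. Since that step stayed within the scatter, the corresponding step on compound 1 is expected to do the same, with no direction beyond the scatter: the expected step is a 1.1-fold lower number from compound 1 to compound 4 (0.04 log units; within the scatter). Compound 4 is therefore estimated at 58000 nM in this assay, within a range from 25000 nM to 140000 nM.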

Compound 4, half-maximal inhibitory concentration: > 100000 nM
Compound 4: only a limit was reported; the forecaster's own chance of this, stated with the estimate: 20%; at least 1.7-fold (0.23 log units) between middle value and limit.
By their numbers in this assay, from the lowest: compounds 1, 3 and 2 (each within the scatter of the next). At a limit, above all of these: compound 4.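

In this assay compound 4 gives > 100000 nM, which is a limit of the assay and not a number. Going by these compounds alone, on the core of compound 1, the exchange of ethoxy for (3-methylbut-2-en-1-yl)oxy can therefore be read only as a floor, an at least 1.5-fold higher number from compound 1 to compound 4 (0.20 log units; that floor lies within the scatter), so this position now has a first reading on a second core, though one that does not separate the two groups. Whether the exchange behaves alike on both cores stays unsettled: the same change on two cores in this assay, a 1.1-fold lower number (0.05 log units; within the scatter) from compound 2 to compound 3 and an at least 1.5-fold higher number (0.20 log units; that floor lies within the scatter) from compound 1 to compound 4; the limit leaves it open whether they differ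

The compounds shown leave open the actual value of compound 4, and so whether the two groups differ at all on this core. They also leave open what a butoxy chain, a methoxy group or a 2-aminoethoxy group would give in place of ethoxy on either core.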